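A few compounds are considered here, and "the series" means these few. Any claim that something is new, unique, unknown or untested is made for them only; others in the source may bear on it.

In an ADME assay on RAW264.7 cells (Mus musculus) for cytotoxicity, read by MTT assay, with a stated time of 24 h (a higher number here means that more compound is tolerated, a lower number that less compound is tolerated), two compounds sharing a core have been measured. Compound 1 `CC/C=C\C[C@H]1C(=O)C=C[C@H]1CC(=O)OCCC` gives 35 uM, while compound 2 `CC/C=C\C[C@H]1C(=O)C=C[C@H]1CC(=O)OCCOCCOC` gives 161 uM, the higher of the two numbers. Going by the values given here, the only measured step, a 4.6-fold higher number from compound 1 to compound 2 (0.66 log units; beyond the scatter), is modest but beyond the scatter, and it bears directly on what follows. Compound 3 `CC/C=C\C[C@H]1C(=O)C=C[C@H]1CC(=O)OC(C)(C)C` has tert-butyl in place of 2-(2-methoxyethoxy)ethyl on an oxygen next to a carbonyl group. Like compound 1, compound 3 lacks the 2-methoxyethoxy part, so the measured step is expected to run roughly in reverse, towards a lower number of similar size. Among the compounds with values here, no measured compound carries tert-butyl, so this expectation remains loose. An estimated step of a 3.6-fold lower number from compound 2 to compound 3 (0.55 log units; beyond the scatter) is therefore expected. For compound 3 the expected value is 45 uM, with an estimated range from 18 uM to 110 uM.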

Compound 3, half-maximal toxic concentration: 33 uM
For compound 3 the middle estimate is 1.4-fold (0.13 log units) above the measured one, and the stated range covers the measured number.
By their numbers in this assay, from the lowest: compounds 3 and 1 (each within the scatter of the next); then compound 2.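

In this assay, tert-butyl in place of 2-(2-methoxyethoxy)ethyl on an oxygen next to a carbonyl group gives a 4.9-fold lower number from compound 2 to compound 3 (0.69 log units; beyond the scatter), while tert-butyl in place of propyl at the same place gives a 1.1-fold lower number from compound 1 to compound 3 (0.03 log units; within the scatter). Among these three compounds, the higher number therefore goes with the 2-(2-methoxyethoxy)ethyl group of compound 2 alone, and the tert-butyl and propyl groups cannot be told apart at this position. Nothing available explains the difference between these groups.

The compounds shown leave open whether the higher number follows the oxygens in the 2-(2-methoxyethoxy)ethyl group or simply its longer chain, a question on which an all-carbon chain such as heptyl would bear. On these data alone, how a chain ending in an amine or a carboxylic acid would read at this place also remains open.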